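This account rests on a few compounds, and the source may have more. Where it says the series, first, only, none or still open, it means among the compounds named here.

Series notes. Compound 1 `c1ccc2c(c1)CN[C@@H](CN(CCCCNCC1CCOCC1)[C@H]1CCCc3cccnc31)C2` carries oxan-4-yl on a saturated chain carbon bound to an amine nitrogen. In a functional assay on cells for agonist activity at C-X-C chemokine receptor type 4 (Homo sapiens), read by fluorescence and calcium flux, with a stated time of 90 s (on this read-out lower numbers stand for an effect already at smaller amounts and higher numbers for an effect only at larger amounts of compound), compound 1 reaches only the assay limit, > 30000 nM. Compound 2 `c1ccc2c(c1)CN[C@@H](CN(CCCCNCC1CCNCC1)[C@H]1CCCc3cccnc31)C2` carries piperidin-4-yl at that place. In this assay compound 2 likewise gives only a limit, > 30000 nM. The step that the two limits leave unreadable from compound 1 to compound 2 is thus unreadable, since both values sit at the limit of > 30000 nM in this assay, at which 2 of the 2 values shown sit. Compound 3 `c1ccc2c(c1)CN[C@@H](CN(CCCCNCC1CCSCC1)[C@H]1CCCc3cccnc31)C2` differs from compound 2 by thian-4-yl in place of piperidin-4-yl on a saturated chain carbon bound to an amine nitrogen. Among the measured compounds shown here, no measured step gives a direction, so for compound 3 a limit is again expected in this assay, the estimate being 30000 nM (range 10000 nM to 100000 nM). The expected step of a number no higher from compound 2 to compound 3 (the limit leaves the size open) is therefore of no readable size.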

Compound 3, half-maximal effective concentration: > 30000 nM
Compound 3 gave a limit, no number (the forecaster's own chance of this, stated with the estimate: 85%); the middle value sits exactly at the limit.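

In this assay the steps among compound 1, compound 2 and compound 3 cannot be read, all three values being limits and not numbers: the limit of > 30000 nM in this assay, at which 3 of the 3 values shown sit. Whether oxan-4-yl, piperidin-4-yl and thian-4-yl differ at all in this assay stays open with the compounds shown.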